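The compounds below may be only part of what the source reports. "The series", "measured", "known", "first", "only" and "open" are said of these compounds alone.

Compound 1: `NC(=S)Nc1cccc(OCCCCCN2CCN(c3ccc(Cl)c(Cl)c3)C2=O)c1`. In an ADME assay on Huh-7 cells (Homo sapiens) for cytotoxicity (a lower number here means that less compound is tolerated, a higher number that more compound is tolerated), compound 1 gives 13000 nM.
Compound 2: `NC(=S)Nc1cccc(OCCCCCCCCNC(=S)Nc2ccccc2)c1`. In this assay compound 2 gives > 50000 nM, which is a limit of the assay and not a number.

Compound 2 therefore sits at the limit of > 50000 nM in this assay, at which 1 of the 2 values shown sits. Compound 3 is `NC(=S)Nc1cccc(OCCCCCCCCNC(=S)Nc2ccc3c(c2)CCC3)c1`; it differs from compound 2 by 2,3-dihydro-1H-inden-5-yl in place of phenyl on an amide-type nitrogen. Going by the values given here, no step between two measured compounds speaks to such a change, so compound 3 is expected to stay close to compound 2, with no movement beyond the scatter of this assay. Compound 3 is estimated at 50000 nM, between 20000 nM and 100000 nM, an expected step of a number no higher from compound 2 to compound 3 (the limit leaves the size open).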

Compound 3, half-maximal cytotoxic concentration: 34000 nM
For compound 3 the middle estimate is 1.5-fold (0.17 log units) above the measured one; measured number inside the range.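

Going by these compounds alone, with 2,3-dihydro-1H-inden-5-yl in place of phenyl on an amide-type nitrogen, this assay now gives a first step for this position: an at least 1.4-fold lower number from compound 2 to compound 3 (0.16 log units; that floor lies within the scatter). Compound 3 gives a measured number, 34000 nM, so the larger group leaves a value that can be read. The true size of the step stays unknown, and it rests on a limit of the assay: the limit of > 50000 nM in this assay, at which 1 of the 3 values shown sits.

The compounds shown leave open how an amine or a carboxylic acid on this aromatic ring would read in this assay. They also leave open what a longer chain would do with either group in place.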